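A few compounds are considered here, and "the series" means these few. Any claim that something is new, unique, unknown or untested is made for them only; others in the source may bear on it.

Measured so far in a functional assay on HL-60 cells (Homo sapiens) for cytotoxicity, read by CellTiter-Blue, with a stated time of 48 h; on this read-out lower numbers stand for stronger inhibition and higher numbers for weaker inhibition:
Compound 1 `CCOC(=O)CC1C(C(=O)OCC)=C(N)Oc2ccc(-c3cccs3)cc21`: > 80000 nM, a limit.
Compound 2 `CCOC(=O)CC1C(C(=O)OCC)=C(N)Oc2ccc(-c3cccnc3)cc21`: 21500 nM.

Among the compounds with values here, compound 2 gives the only true number in this assay, at 21500 nM. Compound 1 remains a limit, (the limit of > 80000 nM in this assay, at which 1 of the 2 values shown sits).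

Compound 3 `CCOC(=O)CC1C(C(=O)OCC)=C(N)Oc2ccc(-c3ccc(N)cc3)cc21` carries 4-aminophenyl in place of pyridin-3-yl on an aromatic carbon of the shared core: 4-aminophenyl in place of pyridin-3-yl on an aromatic carbon.

Within the data shown here, one measured step bears on this place, the exchange of thiophen-2-yl for pyridin-3-yl, an at least 3.7-fold lower number from compound 1 to compound 2 (0.57 log units; beyond the scatter). It is a single step with one end at a limit, and it sets no direction for the new group. A change of modest size at most is therefore expected, in either direction, and most likely none beyond the scatter. The expected step is a 1.1-fold lower number from compound 2 to compound 3 (0.03 log units; within the scatter). For compound 3 the estimated value is 20000 nM. The expected range runs from 7000 nM to 60000 nM.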

Compound 3, half-maximal inhibitory concentration: 22300 nM
For compound 3 the middle estimate is 1.1-fold (0.05 log units) below the measured one, and the stated range covers the measured number.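

In this assay, 4-aminophenyl in place of pyridin-3-yl gives a 1.0-fold higher number from compound 2 to compound 3 (0.02 log units; within the scatter), so the ring nitrogen of pyridin-3-yl is not needed to hold the level of compound 2, and the change in the ring comes with no step beyond the scatter despite the added amine. The exchange of thiophen-2-yl for 4-aminophenyl gives an at least 3.5-fold lower number from compound 1 to compound 3 (0.55 log units; beyond the scatter), so thiophen-2-yl now stands apart from two six-membered aromatic groups instead of one. The size of that gap stays unknown, as compound 1 is a limit and not a number: the limit of > 80000 nM in this assay, at which 1 of the 3 values shown sits.

Unsubstituted phenyl at this position would show whether the amine of compound 3 contributes anything at all. On these data alone, whether the five-membered ring or its sulfur sets compound 1 apart remains open, and furan-2-yl would bear on that.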